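The source may hold more compounds than are shown below. What is called first, only, known or untested is meant among the compounds shown, and "the series" means these compounds.

In a functional assay on HepG2 cells (Homo sapiens) for inhibition, read by MTT assay, with a stated time of 72 h; a higher number here means a weaker inhibitor, a lower number a stronger inhibitor:
- Compound 1 `CC(C)(C)n1cc2c(n1)C(=O)CC1(CCN(C(=O)c3cc(-c4ccccc4)nc4ccccc34)CC1)O2`: 2110 nM
- Compound 2 `CC(C)(C)n1cc2c(n1)C(=O)CC1(CCN(C(=O)c3cc(-c4ccccc4Cl)nc4ccccc34)CC1)O2`: > 10000 nM, a limit of the assay and not a number
- Compound 3 `CC(C)(C)n1cc2c(n1)C(=O)CC1(CCN(C(=O)c3cc(-c4ccc(N)cc4)nc4ccccc34)CC1)O2`: 630 nM

Compound 3 has the lowest number of the three, and compound 1 is its nearest neighbour. Compound 4 `Cc1cc(C(=O)N2CCC3(CC2)CC(=O)c2nn(C(C)(C)C)cc2O3)c2ccccc2n1` carries methyl in place of 4-aminophenyl on an aromatic carbon.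

The measured steps all keep an aromatic ring at this place, so they bear on the change only indirectly. Amino gave a 3.3-fold lower number from compound 1 to compound 3 (0.52 log units; beyond the scatter), chloro gave an at least 4.7-fold higher number from compound 1 to compound 2 (0.67 log units; beyond the scatter), and exchanging the two substituted rings gave an at least 15-fold lower number from compound 2 to compound 3 (1.20 log units; beyond the scatter). Compound 4 loses the amino group behind a 3.3-fold lower number from compound 1 to compound 3 (0.52 log units; beyond the scatter), so a higher number is expected, with the expected step being a 7.9-fold higher number from compound 3 to compound 4 (0.90 log units; beyond the scatter). For compound 4 the estimate is 5000 nM, with an expected range of 1500 nM to 10000 nM.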

Compound 4, half-maximal inhibitory concentration: 9480 nM
Estimate against measurement, compound 4: 1.9-fold (0.28 log units) below; the range from low to high includes it.
By their numbers in this assay, from the lowest: compound 3; then compound 1; then compound 4. At a limit, above all of these: compound 2.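

In this assay, methyl in place of 4-aminophenyl gives a 15-fold higher number from compound 3 to compound 4 (1.18 log units; beyond the scatter), and methyl in place of phenyl gives a 4.5-fold higher number from compound 1 to compound 4 (0.65 log units; beyond the scatter). So the unsubstituted phenyl ring of compound 1, not just the amino group of compound 3, goes with a lower number than methyl. Compound 2 carries a ring too and goes against this pattern: methyl in place of 2-chlorophenyl gives an at least 1.0-fold lower number from compound 2 to compound 4 (0.02 log units; that floor lies within the scatter), a step that cannot be read as a difference. The value of compound 2 is a limit of the assay and not a number: the limit of > 10000 nM in this assay, at which 1 of the 4 values shown sits.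

Still open, on these data alone, is whether the ring itself matters or only the size of the group. A longer chain such as butyl, or a 4-hydroxyphenyl ring, at this place could help to separate the two.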